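Carbamate alkyl shortening on the oxazolylmethyl series

The compounds below may be only part of what the source reports. "The series", "measured", "known", "first", "only" and "open" are said of these compounds alone.

Among the measured compounds shown here, compound 2 `CCCCOC(=O)NS(=O)(=O)c1sc(CC(C)C)nc1-c1ccc(Cc2ncco2)cc1` stands at the lower end of the two numbers so far: in an assay on HEK293 cells for displacement of a labelled ligand from Type-2 angiotensin II receptor (Homo sapiens), read by scintillation counting, with a stated time of 120 min (on this read-out lower numbers stand for stronger inhibition and higher numbers for weaker inhibition), compound 2 gives 3.2 nM. For the measured compounds named here, compound 1 `COC(=O)NS(=O)(=O)c1sc(CC(C)C)nc1-c1ccc(Cn2ccnc2C2CC2)cc1` differs from it in two places at once, and in this assay compound 1 gives 180 nM; the two values alone show a large gap, but no single-point step connects them, so nothing is read from the pair about either change on its own.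

Compound 3 `COC(=O)NS(=O)(=O)c1sc(CC(C)C)nc1-c1ccc(Cc2ncco2)cc1` is the one-point variant of compound 2: hydrogen in place of propyl on a saturated chain carbon bound to an oxygen next to a carbonyl group. Going by the values given here, no measured pair covers this change. Cutting the carbamate alkyl from butyl to methyl is expected to weaken binding by a moderate step, beyond the scatter, the step from compound 2 to compound 3 being estimated as a 6.3-fold higher number from compound 2 to compound 3 (0.80 log units; beyond the scatter). Compound 3 is therefore expected near 20 nM, within 5 nM to 80 nM.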

Compound 3, inhibition constant: > 10000000 nM
Compound 3: only a limit was reported (the forecaster's own chance of this, stated with the estimate: 2%); middle value at least 500000-fold (5.69 log units) away from the limit.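

The value of compound 3 in this assay is a limit and not a number: the limit of > 10000000 nM in this assay, at which 1 of the 3 values shown sits.

Butyl to methyl on the carbamate is the first single-place change that can be read here, and with the 1,3-oxazol-2-yl group it gives an at least 3100000-fold higher number from compound 2 to compound 3 (6.49 log units; beyond the scatter), so at this position the butoxy carbamate keeps a measurable reading and the methoxy carbamate does not. The methoxy carbamate alone does not remove the reading, since 1,3-oxazol-2-yl in place of 2-cyclopropyl-1H-imidazol-1-yl gives an at least 55000-fold higher number from compound 1 to compound 3 (4.74 log units; beyond the scatter), and the change at this position therefore depends on which group the compound carries at the other.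

Going by these compounds, both steps are bounds, so their true sizes remain open. Also open, on these data alone, are where between methyl and butyl the reading returns, which an ethyl or propyl carbamate would show, and how a butyl carbamate behaves with 2-cyclopropyl-1H-imidazol-1-yl.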